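This account rests on a few compounds, and the source may have more. Where it says the series, first, only, none or still open, it means among the compounds named here.

Compound 1 `Nc1scc(CN2CCC(c3ccc(Cl)cc3)CC2)c1C(=O)c1ccc(Cl)cc1` gives 0% in an assay on CHO cells for displacement of a labelled ligand from adenosine receptor A1 (Homo sapiens), read by scintillation counting, with a stated time of 120 min, tested at 10 uM; a lower number here means less inhibition, a higher number more inhibition at the concentration tested (going by the name of the read-out).
Compound 2 `Nc1scc(CN2CCN(c3cccc(F)c3)CC2)c1C(=O)c1cccc(C(F)(F)F)c1` gives 0%.
Compound 3 `Nc1scc(CN2CCN(C3CCCCCC3)CC2)c1C(=O)c1ccc(Cl)cc1` gives 0%.

Compound 3 stands level with compound 1 and compound 2 at the digits shown; its nearest neighbour is compound 1 and its furthest is compound 2, and both gaps fall within the scatter, so no order among the three can be drawn. Compound 4 `Nc1scc(CN2CCN(c3cc(Cl)ccc3Cl)CC2)c1C(=O)c1ccc(Cl)cc1` has not been measured in this assay. The change from compound 3 is 2,5-dichlorophenyl in place of cycloheptyl on an amine nitrogen in a ring. Going by the values given here, no step between two measured compounds is available to guide the expectation, and all three measured readings sit at the same level. The expected step is no change at the digits printed from compound 3 to compound 4 (within the scatter), none beyond the scatter. Compound 4 is expected to give 0%, within -5% to 15%.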

Compound 4, a percentage reported as inhibition, at one concentration (the size of the read-out at that concentration, not a potency): 0%
Beside the measured number, compound 4's estimate shows no gap at the digits printed; measured number inside the range.
By their numbers in this assay, from the lowest: compounds 1, 2, 3 and 4 (each within the scatter of the next).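

In this assay, 2,5-dichlorophenyl in place of cycloheptyl on an amine nitrogen in a ring gives no change at the digits printed from compound 3 to compound 4 (within the scatter). Going by these compounds alone, this is the only step here between compounds that differ in one place, and it shows that an aromatic ring carrying two chlorines and a seven-membered carbon ring read alike at this position. No evidence is available to explain this reading. The compounds shown leave open whether a carboxylic acid, a primary amine or a longer chain on this nitrogen would move the reading at all.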